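This account rests on a few compounds, and the source may have more. Where it says the series, first, only, none or still open, it means among the compounds named here.

Compound 2 `Cc1ccc(S(=O)(=O)NCc2ccc(CNC(=O)c3ccc(F)cc3)cc2)cc1` is the reference point of this pair. In an assay on MDA-MB-231 cells for binding affinity to C-X-C chemokine receptor type 4 (Homo sapiens), read by immunofluorescence and microscopy, with stated times of 10 min and 30 min (a lower number here means that less compound is needed, a higher number that more compound is needed for the effect), compound 2 gives 1 nM, the lowest of the two numbers available. Going by the values given here, the only other measured member is compound 1 `O=C(NCc1ccc(CNS(=O)(=O)c2ccccc2)cc1)c1cccc(F)c1`, which in this assay gives 100 nM; the gap between compound 1 and compound 2 is well beyond the scatter of repeated measurements, but compound 1 differs from compound 2 in two places at once, so the two values show the combined effect and nothing about either change on its own.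

Compound 3 `O=C(NCc1ccc(CNS(=O)(=O)c2ccccc2)cc1)c1ccc(F)cc1` is not yet measured. Relative to compound 2 the change is hydrogen in place of methyl on an aromatic carbon. Among the compounds with values here, with no step between measured compounds isolating this change, the expectation rests on the position of compound 2 alone and on the general observation that a change of this size seldom moves a number far. The estimate for compound 3 in this assay is 5 nM, within a range of 1 nM to 30 nM, which means an expected step from a 5.0-fold higher number from compound 2 to compound 3 (0.70 log units; beyond the scatter), a modest rise that may or may not clear the scatter.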

Compound 3, effective concentration (reported as EC, without a stated level of effect): 100 nM
Beside the measured number, compound 3's estimate is 20-fold (1.30 log units) below it; the measured number lies above the stated range.
By their numbers in this assay, from the lowest: compound 2; then compounds 1 and 3 (each within the scatter of the next).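

In this assay the difference of 4-methylphenyl to phenyl now stands on its own, and a 100-fold higher number from compound 2 to compound 3 (2.00 log units; beyond the scatter) is a large step for the loss of a single methyl from an aromatic carbon para to a large group. The other difference contained in the earlier pair also separates out: with 4-fluorophenyl in place of 3-fluorophenyl on a carbonyl carbon, there is no change at the digits printed from compound 1 to compound 3 (within the scatter), so among these three compounds the whole gap first seen between compound 1 and compound 2 is matched by the methyl step, while the fluorine position, read without the methyl, adds nothing visible. Nothing on hand explains why this methyl matters so much.

From the compounds shown here alone, whether the methyl step keeps its size with 3-fluorophenyl on the carbonyl carbon remains open, as the fluorine position has been read only on the compounds lacking the methyl. Also open, going by these compounds, is whether the position responds to the methyl specifically or would accept another group there, such as an ethyl, a methoxy, a chlorine or an amine.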